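Aryl in place of bromo on the shared core

A few compounds are considered here, and "the series" means these few. Any claim that something is new, unique, unknown or untested is made for them only; others in the source may bear on it.

Compound 3 `O=C(CCCCCCc1ccccc1)c1nc(Br)co1` sits at the limit of an assay on HEK-293T cells for inhibition of diacylglycerol lipase-alpha (Homo sapiens), read by colorimetric assay; on this read-out higher numbers stand for weaker inhibition and lower numbers for stronger inhibition: in this assay compound 3 gives > 10000 nM, a limit and not a number. Compound 2 `COc1coc(C(=O)CCCCCCc2ccccc2)n1` also gives only a limit, > 10000 nM in this assay. Compound 1 `CC(C)(C)C(=O)c1coc(C(=O)CCCCCCc2ccccc2)n1` gives a number, 479 nM in this assay. The steps of an at least 20-fold higher number from compound 1 to compound 2 (1.31 log units; beyond the scatter) and an at least 20-fold higher number from compound 1 to compound 3 (1.31 log units; beyond the scatter) are both large; the step that the two limits leave unreadable from compound 2 to compound 3 stays unreadable, as the limit of > 10000 nM in this assay, at which 2 of the 3 values shown sit, shows. Compound 4 `O=C(CCCCCCc1ccccc1)c1nc(-c2ccncc2)co1` differs from compound 3 by pyridin-4-yl in place of bromo on an aromatic carbon. Among the compounds with values here, no measured step exchanges bromo for a ring, so the direction is open; the measured steps show only that methoxy and bromo on this aromatic carbon fall far behind (tert-butyl)carbonyl. A modest gain is expected, an at least 3.3-fold lower number from compound 3 to compound 4 (0.52 log units; beyond the scatter). Compound 4 is estimated at 3000 nM, within 500 nM to 15000 nM, with a real chance of another limit.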

Compound 4, half-maximal inhibitory concentration: > 10000 nM
Compound 4 ended at the assay's limit; the forecaster's own chance of this, stated with the estimate: 45%; middle value at least 3.3-fold (0.52 log units) from the limit.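

Compound 4 is a limit and not a number, so a six-membered aromatic ring on this aromatic carbon gives no readable inhibition. Pyridin-4-yl therefore joins methoxy and bromo far behind (tert-butyl)carbonyl (an at least 20-fold higher number from compound 1 to compound 4 (1.31 log units; beyond the scatter)). The steps among compounds 2, 3 and 4 cannot be read, and no order among these groups can be given: the limit of > 10000 nM in this assay, at which 3 of the 4 values shown sit.

As far as these compounds go, whether the carbonyl itself carries the gain stays open. A methyl ketone, a methyl ester or an amide here could separate it from the tert-butyl group, and phenyl could test the ring nitrogen.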